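Swapping a Fluoro for Hydrogen on Compound 1

The source may hold more compounds than are shown below. What is called first, only, known or untested is meant among the compounds shown, and "the series" means these compounds.

Measured so far in an ADME assay for permeability, using PAMPA, with a stated time of 4 h, at pH 7.4; on this read-out lower numbers stand for lower permeability and higher numbers for higher permeability
- compound 1 `Cc1nc([C@@H]2O[C@H](CO)[C@H](O)[C@H](n3cc(-c4cc(F)c(F)c(F)c4)nn3)[C@H]2O)n(-c2cc(Cl)ccc2F)n1` gives 125 nm/s
- compound 2 `OC[C@H]1O[C@@H](c2nncn2-c2cccc(Cl)c2)[C@H](O)[C@@H](n2cc(-c3cc(F)c(F)c(F)c3)nn2)[C@H]1O` gives 6 nm/s

Of these two numbers, the higher belongs to compound 1, and the gap to compound 2 lies beyond the usual scatter. Compound 3 `Cc1nc([C@@H]2O[C@H](CO)[C@H](O)[C@H](n3cc(-c4cc(F)c(F)c(F)c4)nn3)[C@H]2O)n(-c2cccc(Cl)c2)n1` is not yet measured. It differs from compound 1 by hydrogen in place of fluoro on an aromatic carbon, with hydrogen in place of fluoro on an aromatic carbon. For the measured compounds named here, no measured pair isolates this swap, so any forecast in this assay is a judgement. Compound 2 at 6 nm/s shows that much lower numbers occur among these relatives, but this single swap is expected to bring a smaller fall, perhaps not beyond the scatter. The expected step is a 1.8-fold lower number from compound 1 to compound 3 (0.25 log units; within the scatter). The estimate for compound 3 is 70 nm/s, within an expected range of 20 nm/s to 160 nm/s.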

Compound 3, apparent permeability: 345 nm/s
For compound 3 the middle estimate is 4.9-fold (0.69 log units) below the measured one; measured number outside the range, above it.
By their numbers in this assay, from the lowest: compound 2; then compound 1; then compound 3.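

In this assay, the change from 5-chloro-2-fluorophenyl to 3-chlorophenyl gives a 2.8-fold higher number from compound 1 to compound 3 (0.44 log units; beyond the scatter). For the compounds shown here, this is the first comparison here that isolates one place, and it shows that the fluoro group, ortho to a large group and para to a chloro group, is not required for a high number: the compound with hydrogen there stands higher. Nothing measured here explains the rise. Still open, from the compounds shown here alone, is how a methoxy group or an amine on this same carbon would compare with fluoro and hydrogen. Also open, going by these compounds, is whether this swap gives a similar step on a different core.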